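Isobutyl Branching Next to the Amide in Two Sulfonamide Pairs

The source may hold more compounds than are shown below. What is called first, only, known or untested is meant among the compounds shown, and "the series" means these compounds.

Compound 1 `CC(=O)c1ccc(NC(=O)CN(C(=O)c2ccccc2)S(=O)(=O)c2ccc([N+](=O)[O-])cc2)cc1` and compound 2 `CC(=O)c1ccc(NC(=O)C(CC(C)C)N(C(=O)c2ccccc2)S(=O)(=O)c2ccc([N+](=O)[O-])cc2)cc1` share a core and differ only by isobutyl in place of hydrogen on a saturated chain carbon bound to an amide-type nitrogen and a carbonyl carbon. In a functional assay for inhibition, read by spectrophotometry, with a stated time of 20 min, tested at 4 mg/mL (a lower number here means a weaker effect, a higher number a stronger effect of the compound at the concentration tested), compound 1 gives 20.7%, while compound 2 gives 71%, so the step is a number 50.3 percentage points higher from compound 1 to compound 2 (beyond the scatter). Compound 3 `CC(=O)c1ccc(NC(=O)CN(C(=O)c2ccccc2)S(=O)(=O)c2ccccc2)cc1` differs from compound 1 by hydrogen in place of nitro on an aromatic carbon, and in this assay compound 3 gives 40.9%, a step of a number 20.2 percentage points higher from compound 1 to compound 3 (beyond the scatter). Compound 4 `CC(=O)c1ccc(NC(=O)C(CC(C)C)N(C(=O)c2ccccc2)S(=O)(=O)c2ccccc2)cc1` is not yet measured; it differs from compound 3 by isobutyl in place of hydrogen on a saturated chain carbon bound to an amide-type nitrogen and a carbonyl carbon, the same change, at the same place, that turned compound 1 into compound 2. The expected step in this assay is therefore a number 44.1 percentage points higher from compound 3 to compound 4 (beyond the scatter), resting on the gain seen in a number 50.3 percentage points higher from compound 1 to compound 2 (beyond the scatter). For compound 4 the estimate in this assay is 85%, likely between 65% and 98%.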

Compound 4, a percentage reported as inhibition, at one concentration (the size of the read-out at that concentration, not a potency): 46.9%
Beside the measured number, compound 4's estimate is 38.1 percentage points above it; measured number below the stated range.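

Carried to the core of compound 3, isobutyl in place of hydrogen gives in this assay a step of a number 6 percentage points higher from compound 3 to compound 4 (within the scatter), so the large gain on the nitro core does not carry over: the same change on two cores in this assay, a number 50.3 percentage points higher (beyond the scatter) from compound 1 to compound 2 and a number 6 percentage points higher (within the scatter) from compound 3 to compound 4, 44.3 percentage points apart, beyond the scatter of two such steps

With isobutyl present, hydrogen in place of nitro gives a number 24.1 percentage points lower from compound 2 to compound 4 (beyond the scatter), the opposite direction to the step without isobutyl: the same change on two cores in this assay, a number 20.2 percentage points higher (beyond the scatter) from compound 1 to compound 3 and a number 24.1 percentage points lower (beyond the scatter) from compound 2 to compound 4, 44.3 percentage points apart, beyond the scatter of two such steps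

So in these four compounds the two changes do not simply add, but the data do not show why, nor how a third core would respond.

As far as these compounds go, it remains open whether a methyl group, a longer chain or an amine on that saturated chain carbon would also depend on the nitro group. From the compounds shown here alone, it is equally open whether another group on the aromatic carbon, such as chlorine or methoxy, would behave like nitro or like hydrogen.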